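Switching the ring on the thiazolidinone nitrogen from pyridine to phenyl

The source may hold more compounds than are shown below. What is called first, only, known or untested is meant among the compounds shown, and "the series" means these compounds.

Measured compounds:
compound 1 `COc1ccc(F)cc1N1C(=O)CSC1c1cccc(C(=O)NCCCCn2cccn2)c1`: 1470 mL.min-1.g-1
compound 2 `O=C(NCCCCc1ccccc1)c1cccc(C2SCC(=O)N2c2ccccn2)c1`: 1480 mL.min-1.g-1
compound 3 `COc1ccccc1N1C(=O)CSC1c1cc(F)cc(C(=O)NCCCCc2ccccc2)c1`: 3260 mL.min-1.g-1

In an ADME assay on microsomes from liver (Rattus norvegicus) for metabolic stability, read by LC-MS, using NADPH, with a stated time of 10 min, tested at 0.1 uM (a higher number here means faster removal of the compound, a lower number slower removal), compound 2 gives 1480 mL.min-1.g-1. Compound 1 lies at the same level, its number being within the scatter of compound 2, while compound 3 sits higher than compound 2 by a gap that is beyond the scatter. Compound 4 `O=C(NCCCCc1ccccc1)c1cccc(C2SCC(=O)N2c2ccc(C3CC3)cc2)c1` has not been measured in this assay. It differs from compound 2 in one place: 4-cyclopropylphenyl in place of pyridin-2-yl on an amide-type nitrogen in a ring. No measured pair shows this same change, so the expectation rests only on the three numbers shown, all of which are high. Compound 4 is expected to stay close to compound 2, with a step of a 1.4-fold higher number from compound 2 to compound 4 (0.13 log units; within the scatter) that lies within the scatter. The estimate for compound 4 is 2000 mL.min-1.g-1, with a range from 1000 mL.min-1.g-1 to 4000 mL.min-1.g-1.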

Compound 4, intrinsic clearance in microsomes: 2280 mL.min-1.g-1
Estimate against measurement, compound 4: 1.1-fold (0.06 log units) below, and the stated range covers the measured number.
By their numbers in this assay, from the lowest: compounds 1, 2, 4 and 3 (each within the scatter of the next, the first and the last beyond it).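

In this assay, for the compounds shown here, placing 4-cyclopropylphenyl instead of pyridin-2-yl on the amide-type nitrogen in the ring gives a 1.5-fold higher number from compound 2 to compound 4 (0.19 log units; within the scatter) and thus the first direct reading at this position. The exchange adds a cyclopropane ring and removes the ring nitrogen and its hydrogen-bond acceptor, yet the step stays within the scatter and the number remains high. Nothing measured here explains this outcome. Going by these compounds, whether a morpholine or a carboxylic acid on the ring at this position would bring a step beyond the scatter remains open.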